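Iodo to Amino on an Aromatic Carbon

The source may hold more compounds than are shown below. What is called first, only, known or untested is meant among the compounds shown, and "the series" means these compounds.

Compound 2 `O=C(CCCCCc1cccc(I)c1)N1CCOC1=O` gives 3120 nM in an assay on HEK293 cells for inhibition of N-acylethanolamine-hydrolyzing acid amidase (Rattus norvegicus), read by LC-MS, with a stated time of 30 min (on this read-out lower numbers stand for stronger inhibition and higher numbers for weaker inhibition), the lowest of the two numbers measured here. Its nearest neighbour is compound 3 `COc1cccc(CCCCCC(=O)N2CCOC2=O)c1`, which gives 16300 nM; the step of a 5.2-fold higher number from compound 2 to compound 3 (0.72 log units; beyond the scatter) is a rise from methoxy in place of iodo. Compound 1 `Cc1ccc(CCCCCC(=O)N2CCOC2=O)cc1C` reaches only the limit > 20000 nM, which is an assay limit and not a number (the limit of > 20000 nM in this assay, at which 1 of the 3 values shown sits).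

Compound 4 `Nc1cccc(CCCCCC(=O)N2CCOC2=O)c1` differs from compound 2 by amino in place of iodo on an aromatic carbon. Among the measured compounds shown here, only one measured step bears on this change, the replacement of iodo by methoxy, and it raised the number. A rise of similar size is therefore expected for compound 4, in the direction of weaker inhibition. The step expected is a 4.5-fold higher number from compound 2 to compound 4 (0.65 log units; beyond the scatter). Compound 4 is estimated at 14000 nM, between 4000 nM and 40000 nM.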

Compound 4, half-maximal inhibitory concentration: > 20000 nM
Compound 4: a limit, no number; the forecaster's own chance of this, stated with the estimate: 30%; at least 1.4-fold (0.15 log units) between middle value and limit.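

In this assay, amino in place of iodo gives an at least 6.4-fold higher number from compound 2 to compound 4 (0.80 log units; beyond the scatter), so amino joins methoxy as a second group on this aromatic carbon that gives weaker inhibition than iodo. Amino in place of methoxy gives an at least 1.2-fold higher number from compound 3 to compound 4 (0.08 log units; that floor lies within the scatter), so these two groups cannot be put in order. Compound 4 gives a limit and not a number: the limit of > 20000 nM in this assay, at which 2 of the 4 values shown sit.

As far as these compounds go, it remains open whether bromo or chloro on this carbon would keep inhibition close to that of compound 2. From the compounds shown here alone, it is also open whether iodo itself matters here, or whether a larger group such as trifluoromethyl would serve as well.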